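The source may report more compounds than this note shows. Statements on the series, on what has been measured and on what is new or still open speak of the compounds shown alone.

Notes on the series in an ADME assay on BJ cells (Homo sapiens) for antiproliferative activity, with a stated time of 72 h; on this read-out higher numbers stand for an effect only at larger amounts of compound and lower numbers for an effect already at smaller amounts.

Compound 3 `COc1ccc(-c2cc(=O)c3c(OC)cc(OC)cc3n2S(=O)(=O)c2cc(F)c(F)c(F)c2)cc1` stands only at a limit of the assay; in this assay compound 3 gives > 65500 nM, which is the limit of > 65500 nM in this assay, at which 1 of the 3 values shown sits, and no number. The two neighbours sit the same way. Compound 1 `COc1ccc(-c2cc(=O)c3c(OC)cc(OC)cc3n2S(=O)(=O)c2ccc(C=O)cc2)cc1` gives in this assay the limit > 34400 nM. Compound 2 `COc1ccc(-c2cc(=O)c3c(OC)cc(OC)cc3n2S(=O)(=O)c2ccc([N+](=O)[O-])cc2)cc1` gives in this assay the limit > 29300 nM. All three steps among them are therefore not readable: a step that the two limits leave unreadable from compound 1 to compound 2, a step that the two limits leave unreadable from compound 1 to compound 3 and a step that the two limits leave unreadable from compound 2 to compound 3. For the measured compounds named here, no measured step in this set gives a size or a direction.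

Compound 4 `COc1ccc(-c2cc(=O)c3c(OC)cc(OC)cc3n2S(=O)(=O)c2ccc(Br)cc2)cc1` differs from compound 3 by 4-bromophenyl in place of 3,4,5-trifluorophenyl on a sulfonyl sulfur. Nothing measured bears on this change beyond the fact that three aryl groups on the sulfonyl sulfur all left this assay at a limit; the step in this assay is therefore expected to be none beyond the scatter, most likely again only a limit. The expected step is an at least 1.3-fold lower number from compound 3 to compound 4 (0.11 log units; that floor lies within the scatter). Compound 4 is estimated at 50000 nM, with a range from 20000 nM to 150000 nM.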

Compound 4, half-maximal effective concentration: > 86200 nM
Compound 4 ended at the assay's limit; the forecaster's own chance of this, stated with the estimate: 80%; middle value at least 1.7-fold (0.23 log units) from the limit.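

In this assay compound 4 gives > 86200 nM, which is a limit of the assay and not a number. Its steps to compound 1, compound 2 and compound 3, all also at limits, cannot be read. The compounds shown leave open how the group on the sulfonyl sulfur affects the read-out.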